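Removing a chloro group from an inactive compound

The source may report more compounds than this note shows. Statements on the series, on what has been measured and on what is new or still open speak of the compounds shown alone.

Results in a physicochemical assay for inhibition, with a stated time of 7 days (a higher number here means a weaker inhibitor, a lower number a stronger inhibitor), for three compounds
- compound 1 `Cc1ccc(C)c(NC(=O)Nc2cccc(Cl)c2)c1` gives "not active" (no number reported)
- compound 2 `Cc1ccc(NC(=O)Nc2cccc(Cl)c2)cc1C` gives "not active" (no number reported)
- compound 3 `O=C(Nc1cccc(Cl)c1)Nc1ccc(Cl)c(Cl)c1` gives 15200 nM

Compound 2 stands without a single number, reported as "not active" (no number reported) in this assay and so grouped with compound 1. Compound 4 `Cc1ccc(NC(=O)Nc2ccccc2)cc1C` has yet to be measured. The change hydrogen in place of chloro on an aromatic carbon puts hydrogen in place of chloro on an aromatic carbon. Going by the values given here, no measured step is available to size this change. With compound 2 at "not active" (no number reported) as the starting point, no gain beyond the scatter is expected in this assay for compound 4, which may well go without a number too. Compound 4 is expected near 30000 nM (estimated range 12000 nM to 80000 nM) if a number is reported at all.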

Compound 4, half-maximal inhibitory concentration: 9000 nM
Beside the measured number, compound 4's estimate is 3.3-fold (0.52 log units) above it; measured number outside the range, below it.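

Going by these compounds alone, compound 2 has no single number while compound 4 gives 9000 nM, so no step between them can be read. The compounds shown leave open how large the effect of removing the chloro group is. Nothing available here explains the result.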